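Adding a double bond to the ester chain

The source may hold more compounds than are shown below. What is called first, only, known or untested is meant among the compounds shown, and "the series" means these compounds.

In an ADME assay on Vero C1008 cells (Chlorocebus sabaeus) for cytotoxicity (on this read-out higher numbers stand for lower toxicity in this test and lower numbers for higher toxicity in this test), compound 1 `COC(=O)CCCNC(=O)c1cc(C)cc2c1NC(C)(C)C=C2C` gives > 30000 nM as a limit of the assay, not an exact number. Compound 3 `COC(=O)/C=C/CNC(=O)c1cc(C)cc2c1NC(C)(C)C=C2C` keeps the core of compound 1 and has 2-(methoxycarbonyl)ethenyl in place of 2-(methoxycarbonyl)ethyl on a saturated chain carbon bound to an amide-type nitrogen, a swap counted as 2-(methoxycarbonyl)ethenyl in place of 2-(methoxycarbonyl)ethyl on a saturated chain carbon bound to an amide-type nitrogen in full. Compound 2 `COC(=O)/C=C/CNC(=O)c1cccc2c1NCCC2` carries the same new chain on another core and gives > 30000 nM as a limit too, so no clear shift in this assay is expected. The expected a number no higher from compound 1 to compound 3 (the limit leaves the size open) stays within the usual scatter. For compound 3 the estimated value is 30000 nM with an expected range from 15000 nM to 60000 nM around it.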

Compound 3, half-maximal cytotoxic concentration: > 30000 nM
Compound 3 was reported as a limit; the forecaster's own chance of this, stated with the estimate: 75%; the middle value sits exactly at the limit.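

Among the compounds shown here, compound 1 and compound 3 both stop at an assay limit, so no step between them can be read: the limit of > 30000 nM in this assay, at which 3 of the 3 values shown sit. The compounds shown leave open whether 2-(methoxycarbonyl)ethenyl and 2-(methoxycarbonyl)ethyl differ at all in cytotoxicity.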